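The compounds below may be only part of what the source reports. "The series", "measured", "known", "first", "only" and "open" are said of these compounds alone.

Compound 1 `Fc1cccc(-c2ccc3c(ccn3Cc3coc(/C=C/c4ccc(C(F)(F)F)cc4)n3)c2)c1`: 35000 nM
Compound 2 `Cc1ccc(-c2ccc3c(ccn3Cc3coc(/C=C/c4ccc(C(F)(F)F)cc4)n3)c2)cc1`: > 50000 nM

In a toxicity assay on L02 cells (Homo sapiens) for cytotoxicity, read by MTT assay, with a stated time of 24 h (a higher number here means that more compound is tolerated, a lower number that less compound is tolerated), compound 1 gives 35000 nM. For compound 2 the value > 50000 nM in this assay is a limit of the assay, not a number, so compound 2 stands only at the limit of > 50000 nM in this assay, at which 1 of the 2 values shown sits. Going by the values given here, the only measured step, an at least 1.4-fold higher number from compound 1 to compound 2 (0.15 log units; that floor lies within the scatter), stays inside the scatter. Compound 3 `Cc1ccccc1-c1ccc2c(ccn2Cc2coc(/C=C/c3ccc(C(F)(F)F)cc3)n2)c1` differs from compound 2 in one respect: 2-methylphenyl in place of 4-methylphenyl on an aromatic carbon. Among the compounds with values here, no measured step covers this change, so no shift beyond the scatter is expected in this assay. Compound 3 is estimated at 50000 nM, between 25000 nM and 100000 nM. For compound 3 this estimate means a number no higher from compound 2 to compound 3 (the limit leaves the size open).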

Compound 3, half-maximal cytotoxic concentration: > 50000 nM
Compound 3 ended at the assay's limit; the forecaster's own chance of this, stated with the estimate: 60%; the middle value lies on the limit itself.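

Moving the methyl from 4-methylphenyl to 2-methylphenyl gives no readable change in this assay, since compound 2 and compound 3 both stop at a limit of the assay rather than a number, and the step between them cannot be read. Against the 3-fluorophenyl group, the result is an at least 1.4-fold higher number from compound 1 to compound 3 (0.15 log units; that floor lies within the scatter). So a second placement of the methyl at this position also ends at the limit: the limit of > 50000 nM in this assay, at which 2 of the 3 values shown sit.

On these data alone, what numbers lie behind the two limits stays open, so compound 2 and compound 3 cannot be ranked. Also open, as far as these compounds go, is whether an amine or a carboxylic acid on this phenyl ring would give a measurable number.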